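A Furan-to-Methoxyphenyl Exchange Awaiting Its Result

The source may hold more compounds than are shown below. What is called first, only, known or untested is meant among the compounds shown, and "the series" means these compounds.

Going by the values given here, compound 2 `N#C/C(=C\c1ccco1)C(=O)NCc1ccc(Cl)c(Cl)c1` holds the only real number in this small set: in a functional assay on SMA cells (Homo sapiens) for inhibition, read by MTT assay, with a stated time of 72 h (a higher number here means a weaker inhibitor of growth, a lower number a stronger inhibitor of growth), compound 2 gives 38000 nM. Compound 1 `COc1ccc(CNC(=O)/C(C#N)=C/c2ccc[nH]2)cc1` reports no number in this assay, only the limit > 50000 nM. Compound 2 therefore stands as the single measured figure, the other value resting at the limit of > 50000 nM in this assay, at which 1 of the 2 values shown sits. Compound 3 `COc1ccc(/C=C(\C#N)C(=O)NCc2ccc(Cl)c(Cl)c2)cc1` keeps the dichloro-substituted benzyl amide of compound 2 and introduces (4-methoxyphenyl in place of furan-2-yl on a double-bonded chain carbon bound to a double-bonded chain carbon). Among the compounds with values here, no step between measured compounds exists, so the expectation leans on compound 1, which also carries the 4-methoxyphenyl on the chain carbon and reaches only its limit > 50000 nM. Compound 3 is accordingly expected to inhibit growth weakly, around 45000 nM, with a plausible range from 20000 nM to 100000 nM. The expected step is a 1.2-fold higher number from compound 2 to compound 3 (0.07 log units; within the scatter), either a small loss in growth inhibition or no change beyond the scatter.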

Compound 3, concentration for 50% growth inhibition: > 100000 nM
Compound 3 gave a limit, no number; the forecaster's own chance of this, stated with the estimate: 40%; at least 2.2-fold (0.34 log units) between middle value and limit.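

Going by these compounds alone, with the dichloro-substituted benzyl amide held constant, this is the first comparison in the set that changes one place only: in this assay, 4-methoxyphenyl in place of furan-2-yl on a double-bonded chain carbon bound to a double-bonded chain carbon gives an at least 2.6-fold higher number from compound 2 to compound 3 (0.42 log units; beyond the scatter). Growth inhibition at this position therefore responds to the exchange, and of the two groups furan-2-yl gives the stronger inhibitor. The step sets only a minimum for the loss, because compound 3 carries a limit rather than a number: the limit of > 100000 nM in this assay, at which 1 of the 3 values shown sits.

On these data alone, the full size of the loss remains open, as does whether it follows from the six-membered ring or from the methoxy group, a question that a plain phenyl or a thiophen-2-yl at this place could address. Compound 1 differs from compound 2 and compound 3 in more than one place and so cannot settle it.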